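The compounds below may be only part of what the source reports. "The series", "measured", "known", "first", "only" and "open" are said of these compounds alone.

Measured so far in an ADME assay on microsomes from liver (Homo sapiens) for metabolic stability, with a stated time of 60 min, tested at 1 uM; a lower number here means that less of the compound is left, a higher number that more of the compound is left:
compound 1 `CNc1nc2c(-c3ccnc(OC)c3)cnn2cc1OC` gives 63%
compound 2 `COc1cc(-c2cnn3cc(OC)c(-c4cc(C)no4)nc23)ccn1` gives 31%
compound 3 `COc1cc(-c2cnn3cc(OC)c(C(C)(C)O)nc23)ccn1` gives 66%

Compound 1 stands second highest of these three numbers in this assay. Its nearest neighbour is compound 3, whose number lies within the scatter of it; its furthest is compound 2, whose number lies far below, beyond the scatter.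

Compound 4 `COc1cc(-c2cnn3cc(OC)c([C@@H]4COC(C)(C)C4)nc23)ccn1` is not yet measured. Against compound 1 the change is a group of 7 heavy atoms (6 carbon, 1 oxygen; one five-membered non-aromatic ring with 1 hetero atom) in place of a group of 2 heavy atoms (1 carbon, 1 nitrogen; no ring), on an aromatic carbon

Among the measured compounds shown here, two measured steps bear on this change, both replacing the same methylamino group on the same aromatic carbon of the shared core. Replacement by 3-methyl-1,2-oxazol-5-yl gave a number 32 percentage points lower from compound 1 to compound 2 (beyond the scatter). Replacement by 1-hydroxy-1-methylethyl gave a number 3 percentage points higher from compound 1 to compound 3 (within the scatter). The entering group of compound 4 is non-aromatic, as is 1-hydroxy-1-methylethyl, yet it is a ring with no hydrogen-bond donor, as is 3-methyl-1,2-oxazol-5-yl. The expected step is therefore placed between the two measured ones, a moderate fall, expected as a number 13 percentage points lower from compound 1 to compound 4 (beyond the scatter). Compound 4 is accordingly estimated at 50%, with a range from 30% to 70%.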

Compound 4, percent of the compound remaining: 13%
For compound 4 the middle estimate is 37 percentage points above the measured one, and the stated range ends above it.
By their numbers in this assay, from the lowest: compound 4; then compound 2; then compounds 1 and 3 (each within the scatter of the next).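

In this assay, among the compounds shown here, the position on the aromatic carbon next to the ring nitrogen and ortho to a methoxy group proves far less tolerant than the earlier compounds suggested: a non-aromatic entering group does not by itself hold the number up, as the five-membered ring with 1 hetero atom gives a large fall from the methylamino compound (a number 50 percentage points lower from compound 1 to compound 4 (beyond the scatter)) and from the other non-aromatic group, 1-hydroxy-1-methylethyl (a number 53 percentage points lower from compound 3 to compound 4 (beyond the scatter)). The ring also falls below the aromatic 3-methyl-1,2-oxazol-5-yl (a number 18 percentage points lower from compound 2 to compound 4 (beyond the scatter)), so the two groups with no hydrogen-bond donor now hold the two lowest numbers, a pattern that no compound shown goes against but that rests on four compounds only. Nothing measured here gives a reason for this result.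

The compounds shown leave open whether the fall follows the ring itself, its defined stereocentre, its two methyl groups or the absence of a donor. The mirror-image ring, a hydroxyl group on the same ring and an open-chain ether such as methoxymethyl in this place would help to separate these readings.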